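The source may report more compounds than this note shows. Statements on the series, on what has been measured and on what is new or still open speak of the compounds shown alone.

Measured so far in an assay for positive allosteric modulation of metabotropic glutamate receptor 3 (Rattus norvegicus); a lower number here means that less compound is needed, a higher number that more compound is needed for the effect:
compound 1 `Cc1c(OCCCCOc2cncc(C(=O)O)c2)ccc(C(=O)CC(C)(C)C)c1O` gives 180 nM
compound 2 `Cc1c(OCCCCOc2ccc(Cl)c(C(=O)O)c2)ccc(C(=O)CC(C)(C)C)c1O` gives 130 nM
compound 3 `Cc1ccc(OCCCCOc2ccc(C(=O)CC(C)(C)C)c(O)c2C)cc1C(=O)O` gives 309 nM

Compound 3 carries the highest of the three numbers; a 1.7-fold higher number from compound 1 to compound 3 (0.23 log units; within the scatter) stays within the scatter, whereas a 2.4-fold higher number from compound 2 to compound 3 (0.38 log units; beyond the scatter) lies beyond it. Compound 4 `Cc1ccc(C(=O)O)cc1OCCCCOc1ccc(C(=O)CC(C)(C)C)c(O)c1C` is not yet measured. It keeps the atoms of compound 3 and joins them differently: 5-carboxy-2-methylphenyl in place of 3-carboxy-4-methylphenyl on an oxygen on a saturated carbon. Within the data shown here, no measured step repeats this rearrangement. The nearest guide is that exchanging the whole aryl group on that oxygen moved the number little: a 1.4-fold lower number from compound 1 to compound 2 (0.14 log units; within the scatter) and a 1.7-fold higher number from compound 1 to compound 3 (0.23 log units; within the scatter) both stayed within the scatter, and only a 2.4-fold higher number from compound 2 to compound 3 (0.38 log units; beyond the scatter) went modestly beyond it. A step within the scatter, with no clear direction, is therefore expected in this assay. Compound 4 is expected at 280 nM, between 120 nM and 650 nM, which means an expected step of a 1.1-fold lower number from compound 3 to compound 4 (0.04 log units; within the scatter).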

Compound 4, half-maximal effective concentration: 892 nM
Compound 4: middle estimate off by 3.2-fold (0.50 log units), on the low side, outside the stated range (above it).
By their numbers in this assay, from the lowest: compounds 2, 1 and 3 (each within the scatter of the next, the first and the last beyond it); then compound 4.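

In this assay the aryl group on the oxygen on a saturated carbon responds to the arrangement of its atoms alone: 5-carboxy-2-methylphenyl in place of 3-carboxy-4-methylphenyl gives a 2.9-fold higher number from compound 3 to compound 4 (0.46 log units; beyond the scatter) with no change in atom count. The same group also stands apart from the other two aryl groups, giving a 6.9-fold higher number from compound 2 to compound 4 (0.84 log units; beyond the scatter) and a 5.0-fold higher number from compound 1 to compound 4 (0.70 log units; beyond the scatter). Nothing available explains this shift. Still open, as far as these compounds go, is whether the methyl or the carboxy group carries the step, and how a tetrazole in place of the carboxylic acid would read.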